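Chloro in Place of Fluoro: An Expectation for Compound 4

This account rests on a few compounds, and the source may have more. Where it says the series, first, only, none or still open, it means among the compounds named here.

Four compounds share a core, and three of them have been tested. Compound 1 `Cc1ccc(/C=C2\CN(C(=S)SCc3cn(Cc4ccccc4F)nn3)C/C(=C\c3ccc(C)cc3)C2=O)cc1` in a functional assay on 4T1 cells (Mus musculus) for cytotoxicity, read by MTT assay, with a stated time of 24 h (a higher number here means a weaker inhibitor, a lower number a stronger inhibitor), gives 28400 nM. Compound 2 `Cc1ccc(/C=C2\CN(Cc3cn(Cc4ccccc4F)nn3)C/C(=C\c3ccc(C)cc3)C2=O)cc1` gives 18000 nM in this assay, and compound 3 `Cc1ccc(/C=C2\CN(Cc3cn(Cc4ccccc4Cl)nn3)C/C(=C\c3ccc(C)cc3)C2=O)cc1` gives 23200 nM. Compound 2 and compound 3 differ by chloro in place of fluoro on an aromatic carbon, and that change made a 1.3-fold higher number from compound 2 to compound 3 (0.11 log units; within the scatter). Compound 4 `Cc1ccc(/C=C2\CN(C(=S)SCc3cn(Cc4ccccc4Cl)nn3)C/C(=C\c3ccc(C)cc3)C2=O)cc1` has not been measured; it differs from compound 1 by chloro in place of fluoro on an aromatic carbon, the same change. The difference between the cores of compound 1 and compound 2 is not broken down here. Because a 1.3-fold higher number from compound 2 to compound 3 (0.11 log units; within the scatter) stayed within the scatter, a step of similar size is expected: a 1.3-fold higher number from compound 1 to compound 4 (0.10 log units; within the scatter). Compound 4 is thus estimated at 36000 nM, with the likely range running from 17000 nM to 76000 nM.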

Compound 4, half-maximal inhibitory concentration: 49300 nM
Compound 4: middle estimate off by 1.4-fold (0.14 log units), on the low side, and the stated range covers the measured number.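

Chloro in place of fluoro gave a 1.7-fold higher number from compound 1 to compound 4 (0.24 log units; within the scatter) in this assay and, set beside the earlier step on the other core, the two steps do not differ: the same change on two cores in this assay, a 1.3-fold higher number (0.11 log units; within the scatter) from compound 2 to compound 3 and a 1.7-fold higher number (0.24 log units; within the scatter) from compound 1 to compound 4, 1.3-fold (0.13 log units) apart, within the scatter of two such steps.
Within these two pairs, then, the change carries from one core to the other with no detectable difference in size. It does not show that the change itself has any effect in this assay: each step lies within the scatter, and two pairs set no rule for the wider series.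

The compounds shown leave open how bromo, methoxy or an amine would behave at the same place. They also leave open whether the same swap would read alike on a core carrying a longer chain.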